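Propargylamine in place of benzylamine on the benzylindole core

The source may report more compounds than this note shows. Statements on the series, on what has been measured and on what is new or still open speak of the compounds shown alone.

Compound 1 `c1ccc(CNCc2cn(Cc3ccccc3)c3ccccc23)cc1` carries a benzylamino group. In an assay on isolated protein for inhibition of Amine oxidase [flavin-containing] B (Rattus norvegicus) (on this read-out higher numbers stand for weaker inhibition and lower numbers for stronger inhibition), compound 1 gives 362000 nM, the highest of the two numbers recorded. Compound 2 `CC#CCN(C)Cc1cc2cc(O)ccc2n1C` gives 8800 nM in this assay, a markedly lower number. Compound 3 `C#CCN(C)Cc1cn(Cc2ccccc2)c2ccccc12` differs from compound 1 by methyl(propargyl)amino in place of benzylamino on a saturated chain carbon bound to an aromatic carbon. Within the data shown here, no measured step covers this exact change. A sizeable move toward lower numbers in this assay is expected because compound 2 shows 8800 nM while also carrying a methylated amine with a short alkyne chain. For compound 3 the value is estimated at 15000 nM, within 2000 nM to 100000 nM, the expected step being a 24-fold lower number from compound 1 to compound 3 (1.38 log units; beyond the scatter).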

Compound 3, inhibition constant: 476000 nM
Estimate against measurement, compound 3: 32-fold (1.50 log units) below, and the stated range ends below it.
By their numbers in this assay, from the lowest: compound 2; then compounds 1 and 3 (each within the scatter of the next).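

On the shared core, on a saturated chain carbon bound to an aromatic carbon, methyl(propargyl)amino in place of benzylamino gives a 1.3-fold higher number from compound 1 to compound 3 (0.12 log units; within the scatter) in this assay and so leaves the read-out without a resolved change. At this place, the two amino groups are not told apart, although one carries an aromatic ring and the other a triple bond. Nothing measured here speaks to the cause of this result.

Open, on these data alone, is whether propargylamino without the methyl, or dimethylamino, on the same chain carbon would give a number outside the scatter of these two. Compound 2 differs from compound 3 in more than one place, so no single change can be tied to its printed value.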